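The source may hold more compounds than are shown below. What is called first, only, known or untested is meant among the compounds shown, and "the series" means these compounds.

Measured compounds in a toxicity assay on CCRF-CEM cells (Homo sapiens) for cytotoxicity; on this read-out lower numbers stand for higher toxicity in this test and higher numbers for lower toxicity in this test:
compound 1 `COc1cccc2c1nc(-c1c(F)cccc1F)n2Cc1c(F)cccc1F` — 44.3 uM
compound 2 `CC(C)=CCc1cccc2c1nc(-c1c(F)cccc1F)n2Cc1c(F)cccc1F` — 28.3 uM

Compound 2 holds the lower of the two numbers in this assay; compound 1 stands nearest, and the step of a 1.6-fold lower number from compound 1 to compound 2 (0.19 log units; within the scatter) lies within the scatter, so no order between the two is claimed. Compound 3 `[N-]=[N+]=NCc1cccc2c1nc(-c1c(F)cccc1F)n2Cc1c(F)cccc1F` has not been measured. It differs from compound 2 by azido in place of 2-methylprop-1-en-1-yl on a saturated chain carbon bound to an aromatic carbon. Going by the values given here, the only measured step, a 1.6-fold lower number from compound 1 to compound 2 (0.19 log units; within the scatter), concerns a different exchange, methoxy against 3-methylbut-2-en-1-yl on an aromatic carbon, and it stayed within the scatter. Among the compounds with values here, no measured step covers an exchange at a saturated chain carbon bound to an aromatic carbon, and no azido compound has been measured. The data thus give no basis for a step beyond the scatter in either direction. The expectation for compound 3 in this assay is therefore a number close to that of compound 2, with a step of a 1.1-fold higher number from compound 2 to compound 3 (0.03 log units; within the scatter) that stays within the scatter. Compound 3 is estimated at 30 uM, with a range from 12 uM to 75 uM. No exchange of this kind has been measured; the range is set wide for that reason.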

Compound 3, half-maximal toxic concentration: > 100 uM
Compound 3 gave a limit, no number; the forecaster's own chance of this, stated with the estimate: 5%; middle value at least 3.3-fold (0.52 log units) from the limit.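

Azido in place of 2-methylprop-1-en-1-yl on a saturated chain carbon bound to an aromatic carbon gives, in this assay, an at least 3.5-fold higher number from compound 2 to compound 3 (0.54 log units; beyond the scatter), so this position responds to a change of group, which the earlier exchange, a 1.6-fold lower number from compound 1 to compound 2 (0.19 log units; within the scatter), did not show. Read as azidomethyl in place of methoxy on an aromatic carbon, the change gives an at least 2.2-fold higher number from compound 1 to compound 3 (0.35 log units; beyond the scatter), so compound 3 stands apart from both earlier compounds, and on this read-out the direction is towards lower toxicity in this test. The entry for compound 3 is a limit of the assay and not a number: the limit of > 100 uM in this assay, at which 1 of the 3 values shown sits.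

The compounds shown leave open whether the higher number belongs to azido alone or also comes with other groups on this saturated chain carbon, such as an amine, a carboxylic acid or a longer chain. They also leave open whether azidomethyl keeps this standing with the other groups of the shared core changed, as all three compounds carry the same two difluorinated aryl parts.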